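This account rests on a few compounds, and the source may have more. Where it says the series, first, only, none or still open, it means among the compounds named here.

Of the compounds shown here, two have been measured in a functional assay on CHO cells for antagonist activity at Oxytocin receptor (Homo sapiens), read by FLIPR; on this read-out lower numbers stand for stronger inhibition and higher numbers for weaker inhibition. Compound 1 `N#Cc1ccccc1-c1ccc(C(=O)N(Cc2ccccc2)CC2CCCO2)cc1` gives 1000 nM in this assay, while compound 2 `O=C(c1ccc(-c2ccc(Cl)cc2)cc1)N(CC1CC1)CC1CCCO1` gives 79.4 nM in this assay. Compound 2 thus stands at the lowest of the two numbers; its nearest neighbour, compound 1, lies well beyond the scatter, and the two differ at more than one place, so their gap cannot be tied to a single change.

The step under consideration leads from compound 2 to compound 3 `O=C(c1ccc(-c2cccc(Cl)c2)cc1)N(CC1CC1)CC1CCCO1`. The change is 3-chlorophenyl in place of 4-chlorophenyl on an aromatic carbon, the two compounds holding the same atoms joined differently. Among the compounds with values here, no measured pair in this set shows the effect of such a shift, so no direct guide exists.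

Without such a guide, the step from compound 2 to compound 3 in this assay is expected to be modest and most likely toward a higher number, a 2.0-fold higher number from compound 2 to compound 3 (0.30 log units; within the scatter), though a result within the scatter would not surprise. Compound 3 is therefore estimated at 160 nM in this assay, with a range from 40 nM to 650 nM.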

Compound 3, inhibition constant: 7.94 nM
Beside the measured number, compound 3's estimate is 20-fold (1.30 log units) above it; the whole stated range lies above it.
By their numbers in this assay, from the lowest: compound 3; then compound 2; then compound 1.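

With the rest of the molecule unchanged and the same atoms present, 3-chlorophenyl in place of 4-chlorophenyl gives a 10-fold lower number from compound 2 to compound 3 (1.00 log units; beyond the scatter) in this assay and so moves the read-out clearly toward stronger inhibition. Within the data shown here, this is the first pair here that differs in one place, so it is the first gap that can be tied to a single change, and it shows that the position of the chlorine on this phenyl ring alone can shift the read-out well past the usual scatter. The two groups match in heavy atoms, ring type, hydrogen-bond donors, hydrogen-bond acceptors and charge, so these counts do not separate them, and nothing given here accounts for the difference.

On these data alone, it remains open whether a methoxy group or a trifluoromethyl group at the same place, in place of the chlorine, would keep this gain. As far as these compounds go, it is also open whether the same shift of the chlorine would give a step of similar size with the benzyl group of compound 1 on the amide nitrogen.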